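Removing a Fluorine from a Benzyl Amide

The source may hold more compounds than are shown below. What is called first, only, known or untested is meant among the compounds shown, and "the series" means these compounds.

compound 1 `CN(C)CCCCCSC1=Nc2ccccc2C(CC(=O)NCc2ccccc2)N1c1ccc(-c2ccccc2)cc1`: 83.9%
compound 2 `CN(C)CCCCCSC1=Nc2ccccc2C(CC(=O)NCc2ccc(F)cc2)N1c1ccccc1`: 7%

In an assay on cells for inhibition of Voltage-dependent T-type calcium channel subunit alpha-1H (Homo sapiens), read by patch clamp, tested at 10 uM (on this read-out lower numbers stand for less inhibition and higher numbers for more inhibition at the one concentration tested (going by the name of the read-out)), compound 2 stands lowest of the two numbers; compound 1 lies higher by a margin beyond the usual scatter. Compound 3 `CN(C)CCCCCSC1=Nc2ccccc2C(CC(=O)NCc2ccccc2)N1c1ccccc1` differs from compound 2 in one place: hydrogen in place of fluoro on an aromatic carbon. For the measured compounds named here, no measured pair shows this change on its own, and compound 1 differs from compound 2 in more than this one place, so its number cannot be read as the effect of the fluorine alone. For compound 3 a step of a number 8 percentage points higher from compound 2 to compound 3 (within the scatter) is expected, small and likely within the scatter, tending slightly upward. Compound 3 is therefore estimated at 15%, with a range from 0% to 50%.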

Compound 3, a percentage reported as inhibition, at one concentration (the size of the read-out at that concentration, not a potency): 51.8%
For compound 3 the middle estimate is 36.8 percentage points below the measured one, and the stated range ends below it.
By their numbers in this assay, from the lowest: compound 2; then compound 3; then compound 1.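

In this assay, the change from 4-fluorobenzyl to benzyl is far from silent: it gives a number 44.8 percentage points higher from compound 2 to compound 3 (beyond the scatter), so this one atom on the amide side matters. Compound 3 also isolates a second place, where hydrogen replacing phenyl on the other aromatic ring gives a number 32.1 percentage points lower from compound 1 to compound 3 (beyond the scatter), so both sites affect the read-out. Nothing measured here explains either step. From the compounds shown here alone, whether chlorine or a methoxy group at the fluorine's place would behave like fluorine or like hydrogen remains open, as does the result of combining the 4-fluorobenzyl amide with the phenyl group.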